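The compounds below may be only part of what the source reports. "The series", "measured", "known", "first", "only" and "open" are said of these compounds alone.

Working notes on the series in an ADME assay on HepG2 cells (Homo sapiens) for cytotoxicity, read by MTT assay, with a stated time of 72 h; on this read-out lower numbers stand for higher toxicity in this test and higher numbers for lower toxicity in this test. Compound 1 (`CC(C)(C)Nc1nc2cc(-c3ccc(Br)cc3)sc2c(=O)[nH]1`) gives 1400 nM and compound 2 (`CC(C)(C)Nc1nc2cc(-c3ccccc3)sc2c(=O)[nH]1`) gives 12500 nM, so compound 2 stands at the higher of the two numbers, the lower toxicity in this test.

Compound 3 (`Cc1cccc(-c2cc3nc(NC(C)(C)C)[nH]c(=O)c3s2)c1`) is the next to be read. The change from compound 2 is methyl in place of hydrogen on an aromatic carbon, in words methyl in place of hydrogen on an aromatic carbon, or phenyl to 3-methylphenyl.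

For the measured compounds named here, only one measured step bears on it, an 8.9-fold higher number from compound 1 to compound 2 (0.95 log units; beyond the scatter), which is hydrogen in place of bromo on an aromatic carbon. That step shows that a group on the aromatic ring can move the number in this assay beyond the scatter, with the bromo compound lower. Going by the values given here, no measured compound carries methyl, however, and bromo is a different group, so this step gives only a rough upper scale.

A smaller move toward a lower number is expected, about the size of the usual scatter, and the estimated step is a 1.8-fold lower number from compound 2 to compound 3 (0.25 log units; within the scatter). For compound 3 the expected value is 7000 nM, with an estimated range from 2800 nM to 16000 nM.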

Compound 3, half-maximal cytotoxic concentration: 14100 nM
The estimate for compound 3 lay 2.0-fold (0.30 log units) below the measured number; measured number inside the range.
By their numbers in this assay, from the lowest: compound 1; then compounds 2 and 3 (each within the scatter of the next).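

In this assay, methyl in place of hydrogen on an aromatic carbon, meta to a large group, gives a 1.1-fold higher number from compound 2 to compound 3 (0.05 log units; within the scatter), so this change leaves compound 2 and compound 3 within the scatter of each other. The step of a 10-fold higher number from compound 1 to compound 3 (1.00 log units; beyond the scatter) is of a size with an 8.9-fold higher number from compound 1 to compound 2 (0.95 log units; beyond the scatter), which places compound 1 alone at the low end of the three, and compound 3 shows that a group added to this phenyl ring does not by itself bring the number down. No evidence bears on the reason for this difference between the bromo and methyl compounds.

Since the bromo of compound 1 and the methyl of compound 3 sit at different places on the ring, the compounds shown do not separate the effect of the group from that of its place, and that question would need bromo at the place methyl holds in compound 3, or methyl at the place bromo holds in compound 1. From the compounds shown here alone, how an amine or a carboxylic acid on this ring would read also remains open.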